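Swapping a pyridyl arm for an imide: solubility outlook

The compounds below may be only part of what the source reports. "The series", "measured", "known", "first", "only" and "open" are said of these compounds alone.

Compound 1, `COc1ccc2[nH]c(C(=O)N3CC(=O)N(Cc4ccccc4)[C@@H](CN4CCC(OC)CC4)C3)cc2c1`: in a physicochemical assay for solubility, read by spectrophotometry, in phosphate buffer, with a stated time of 2 h, at pH 7.4 (a higher number here means a more soluble compound, a lower number a less soluble compound), compound 1 gives > 25000 nM, which is a limit of the assay and not a number.
Compound 2, `COc1ccc2[nH]c(C(=O)N3CC(=O)N(Cc4ccccc4)[C@@H](Cc4ccccn4)C3)cc2c1`: in this assay compound 2 gives > 100000 nM, which is likewise a limit.

Compound 2 therefore stands only at a limit, (the limit of > 100000 nM in this assay, at which 1 of the 2 values shown sits), and compound 1 also sits at a limit, (the limit of > 25000 nM in this assay, at which 1 of the 2 values shown sits). The step that the two limits leave unreadable from compound 1 to compound 2 between them cannot be given a size, since both readings are limits. Compound 3, `COc1ccc2[nH]c(C(=O)N3CC(=O)N(Cc4ccccc4)[C@@H](CN4C(=O)c5ccccc5C4=O)C3)cc2c1`, differs from compound 2 in one place: a group of 11 heavy atoms (8 carbon, 1 nitrogen, 2 oxygen; one five-membered non-aromatic ring with 1 hetero atom, one six-membered aromatic ring of carbon only) in place of a group of 6 heavy atoms (5 carbon, 1 nitrogen; one six-membered aromatic ring with 1 hetero atom), on a saturated chain carbon bound to a saturated ring carbon. Among the compounds with values here, no measured step bears directly on this change, and the only two values recorded are limits, so nothing measured here tells its size. Compound 3 is nevertheless expected to fall in solubility relative to compound 2, by a step estimated at an at least 3.3-fold lower number from compound 2 to compound 3 (0.52 log units; beyond the scatter). Compound 3 is estimated to give 30000 nM in this assay, with an expected range from 8000 nM to 100000 nM.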

Compound 3, solubility: > 100000 nM
Compound 3 was reported as a limit; the forecaster's own chance of this, stated with the estimate: 35%; at least 3.3-fold (0.52 log units) between middle value and limit.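

In this assay compound 3 gives > 100000 nM, which is a limit. Within the data shown here, compound 1, compound 2 and compound 3 all stand at limits, and no step among them can be read. On these data alone, how the three actually rank in solubility remains open.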